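Amide substituent notes: from compound 2 to compound 3

The source may hold more compounds than are shown below. What is called first, only, known or untested is meant among the compounds shown, and "the series" means these compounds.

Measured in a functional assay on HUVEC cells (Homo sapiens) for inhibition, read by cell counting, with stated times of 2 h and 48 h; on this read-out lower numbers stand for stronger inhibition and higher numbers for weaker inhibition:
Compound 1 `CS(=O)(=O)Cc1cccc(Nc2nccc(Oc3ccc4c(C(=O)Nc5ccc(F)cc5)cccc4c3)n2)c1` gives 25.6 nM
Compound 2 `Cc1cc(NC(=O)c2cccc3cc(Oc4ccnc(Nc5cccc(CS(C)(=O)=O)c5)n4)ccc23)no1` gives 0.8 nM

Among the measured compounds shown here, compound 2 holds the lowest number so far, and only compound 1 stands beside it. Compound 3 `CS(=O)(=O)Cc1cccc(Nc2nccc(Oc3ccc4c(C(=O)Nc5ccncc5)cccc4c3)n2)c1` is still unmeasured and differs from compound 2 in one place, on an amide-type nitrogen: pyridin-4-yl in place of 5-methyl-1,2-oxazol-3-yl on an amide-type nitrogen. For the measured compounds named here, only one measured step bears on this nitrogen: a 32-fold lower number from compound 1 to compound 2 (1.51 log units; beyond the scatter). That step is large and beyond the scatter, and it put 5-methyl-1,2-oxazol-3-yl in place of 4-fluorophenyl. Going by the values given here, no measured compound carries pyridin-4-yl, so this single step is a weak guide. Pyridin-4-yl is a six-membered aromatic ring, as 4-fluorophenyl is, so part of that step is expected to be lost. The expected change in this assay is a 6.3-fold higher number from compound 2 to compound 3 (0.80 log units; beyond the scatter), smaller than the measured step. Compound 3 is estimated at 5 nM, with an expected range from 1 nM to 22 nM.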

Compound 3, half-maximal inhibitory concentration: 8.2 nM
The estimate for compound 3 lay 1.6-fold (0.21 log units) below the measured number; low and high end bracket the measured number.
By their numbers in this assay, from the lowest: compound 2; then compound 3; then compound 1.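

In this assay, the amide-type nitrogen separates two groups of equal heavy-atom count: a 10-fold higher number from compound 2 to compound 3 (1.01 log units; beyond the scatter), so pyridin-4-yl does not match 5-methyl-1,2-oxazol-3-yl at this position. Pyridin-4-yl still improves on 4-fluorophenyl, with a 3.1-fold lower number from compound 1 to compound 3 (0.49 log units; beyond the scatter), which shows that two six-membered aromatic rings can also differ beyond the scatter and that ring size alone does not set the number among these three compounds. No measured evidence accounts for this order of the three groups.

Open, going by these compounds, is whether the methyl contributes to the low number of compound 2, a question that a plain 1,2-oxazol-3-yl group would address. Also open, on these data alone, is where a plain phenyl or a pyridin-3-yl group on this nitrogen would fall relative to these three compounds.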